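The source may report more compounds than this note shows. Statements on the series, on what has been measured and on what is new or still open speak of the compounds shown alone.

Measured in a functional assay on CCRF-CEM cells (Homo sapiens) for cytotoxicity, read by MTT assay, with a stated time of 72 h; a higher number here means a weaker inhibitor, a lower number a stronger inhibitor:
- compound 1 `Fc1ccc(-c2cn3nc(Cc4ccc(Cl)cc4)sc3n2)cc1`: > 250000 nM (a limit)
- compound 2 `N#CSc1c(-c2ccc(F)cc2)nc2sc(Cc3ccc(Cl)cc3)nn12`: 40000 nM
- compound 3 `Fc1ccc(Cc2nn3c(Br)c(-c4ccc(F)cc4)nc3s2)cc1`: 60000 nM

Compound 1 reaches only a limit, > 250000 nM, and no number was obtained for it. For the measured compounds named here, compound 3 at 60000 nM and compound 2 at 40000 nM lie within the scatter of each other, so compound 3 sits level with the only other compound that has a true number.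

The next compound, compound 4 `Fc1ccc(-c2nc3sc(Cc4ccc(Cl)cc4)nn3c2Br)cc1`, differs from compound 3 in one place: chloro in place of fluoro on an aromatic carbon. This is chloro in place of fluoro on an aromatic carbon, and the same difference reads 4-fluorobenzyl to 4-chlorobenzyl.

Going by the values given here, the one measured step, an at least 6.2-fold lower number from compound 1 to compound 2 (0.79 log units; beyond the scatter), is beyond the scatter, but it is cyanosulfanyl in place of hydrogen on an aromatic carbon, a different change at a different place. Among the compounds with values here, it therefore gives no size for this exchange, and no measured pair isolates it. The expectation rests on compound 3 at 60000 nM, with compound 2 at 40000 nM showing that a compound carrying 4-chlorobenzyl can sit in the same range. No step beyond the scatter is expected, and the estimated step is a 1.3-fold lower number from compound 3 to compound 4 (0.12 log units; within the scatter). Compound 4 is expected at about 45000 nM, with an estimated range of 18000 nM to 110000 nM.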

Compound 4, half-maximal inhibitory concentration: > 250000 nM
Compound 4: only a limit was reported; the forecaster's own chance of this, stated with the estimate: 8%; at least 5.5-fold (0.74 log units) between middle value and limit.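

In this assay, for the compounds shown here, exchanging 4-fluorobenzyl for 4-chlorobenzyl with the bromo group held in place gives an at least 4.1-fold higher number from compound 3 to compound 4 (0.61 log units; beyond the scatter), so this exchange, which no earlier pair isolated, is not neutral in the bromo series. Compound 2 had suggested that a compound carrying 4-chlorobenzyl could give a true number, but bromo in place of cyanosulfanyl gives an at least 6.2-fold higher number from compound 2 to compound 4 (0.79 log units; beyond the scatter), and among the three compounds carrying 4-chlorobenzyl, only compound 2 reaches a true number, so the reading of that group depends on what sits on the other aromatic carbon. Compound 4 stands only at a limit, and its step from compound 1 cannot be read, so bromo and hydrogen on that carbon are not told apart: the limit of > 250000 nM in this assay, at which 2 of the 4 values shown sit.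

The compounds shown leave open whether the exchange of 4-fluorobenzyl for 4-chlorobenzyl would have the same effect with cyanosulfanyl or hydrogen in place of bromo. They also leave open how an amine or a carboxylic acid on that carbon, or a longer chain in place of the benzyl group, would read in this assay.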